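Triazole-linked enones against prostate cancer cells

This account rests on a few compounds, and the source may have more. Where it says the series, first, only, none or still open, it means among the compounds named here.

Three compounds have been measured in a functional assay on PC-3 cells (Homo sapiens) for antiproliferative activity, read by MTT assay, with a stated time of 48 h; a higher number here means a weaker inhibitor, a lower number a stronger inhibitor:

compound 1, `COc1cccc(-n2cc(COc3ccc(/C=C/C(C)=O)cc3OC)nn2)c1`: compound 1 gives 31600 nM
compound 2, `COc1cc(/C=C/C(C)=O)ccc1OCc1cn(-c2ccc(NC(=O)c3ccccc3)cc2)nn1`: compound 2 gives 76800 nM
compound 3, `COc1cc(/C=C/C(C)=O)ccc1OCc1cn(-c2ccccc2Cl)nn1`: compound 3 gives 48000 nM

Compound 2 holds the highest of the three numbers. Its gap to compound 3 lies within the scatter of this assay, so no order between these two can be claimed, whereas its gap to compound 1 lies beyond the scatter, so compound 2 is the weaker inhibitor of that pair.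

Compound 4, `COc1cc(/C=C/C(C)=O)ccc1OCc1cn(-c2ccc(-c3ccccc3)cc2)nn1`, differs from compound 2 by phenyl in place of benzamido on an aromatic carbon. Among the measured compounds shown here, only one measured step exists in this set, a 1.5-fold higher number from compound 1 to compound 3 (0.18 log units; within the scatter), and it concerns the aryl group on the aromatic nitrogen rather than a substituent on that aryl group, so no measured step bears directly on the change from compound 2 to compound 4. For the measured compounds named here, the one step available was within the scatter, and nothing in the data points to a particular direction for the new change. Compound 4 is therefore expected to give a number close to that of compound 2, with a step of a 1.4-fold lower number from compound 2 to compound 4 (0.14 log units; within the scatter) that is not expected to exceed the scatter. The estimate for compound 4 in this assay is 55000 nM, with a range from 20000 nM to 150000 nM.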

Compound 4, half-maximal inhibitory concentration: 56800 nM
Beside the measured number, compound 4's estimate is 1.0-fold (0.01 log units) below it; the measured number falls inside the stated range.
By their numbers in this assay, from the lowest: compounds 1, 3, 4 and 2 (each within the scatter of the next, the first and the last beyond it).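

In this assay, the change at this position, on an aromatic carbon of a six-membered aromatic ring of carbon only, para to a large group, gives a 1.4-fold lower number from compound 2 to compound 4 (0.13 log units; within the scatter). Among the compounds shown here, this is the first measured step at this place, and it shows that the two groups cannot be told apart here, even though phenyl has fewer heavy atoms than benzamido and carries neither the hydrogen-bond donor nor the hydrogen-bond acceptor of the amide. No independent evidence accompanies this result to explain it.

Both groups carry one six-membered aromatic ring of carbon only, so the compounds shown leave open what happens at this place when a group without such a ring stands there, such as a primary amine, a carboxylic acid or a short alkyl chain. They also leave open whether any of these groups, or a benzyloxy group with its longer link to the ring, would give a number that differs from that of compound 4 by more than the scatter.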